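Trifluoromethyl to methyl on the benzamide: a repeated step

This account rests on a few compounds, and the source may have more. Where it says the series, first, only, none or still open, it means among the compounds named here.

The series is a set of acylated aminopyrazolopyrimidines tested in a functional assay on CHO cells for antagonist activity at adenosine receptor A2b (Homo sapiens), read by 33P incorporation, with a stated time of 20 min, in the presence of a further agent that is not named here; on this read-out lower numbers stand for stronger inhibition and higher numbers for weaker inhibition. Compound 1 `Cc1ccc(C(=O)Nc2nc(Cl)c3cn(C)nc3n2)cc1` and compound 2 `Cn1cc2c(Cl)nc(NC(=O)c3ccc(C(F)(F)F)cc3)nc2n1` share one core; compound 3 `CCOC(=O)c1nc(NC(=O)c2ccc(C(F)(F)F)cc2)nc2nn(CC(C)(C)C)cc12` carries a second core, and the difference between the two cores is not broken down here.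

In this assay compound 2 gives > 20000 nM, which is a limit of the assay and not a number. Compound 1 gives > 20000 nM in this assay, likewise a limit. Compound 3 gives > 20000 nM in this assay, again a limit. All three therefore sit at the same point, (the limit of > 20000 nM in this assay, at which 3 of the 3 values shown sit), and no ranking among them can be read.

The change from compound 2 to compound 1 is methyl in place of trifluoromethyl on an aromatic carbon. Its size, a step that the two limits leave unreadable from compound 2 to compound 1, cannot be read, since both ends are limits.

The unmeasured compound 4 `CCOC(=O)c1nc(NC(=O)c2ccc(C)cc2)nc2nn(CC(C)(C)C)cc12` is related to compound 3 by the same kind of change: methyl in place of trifluoromethyl on an aromatic carbon. Both places are described in the same words. The step from compound 3 to compound 4 in this assay is expected to be small or unreadable, a step that the limit leaves unreadable from compound 3 to compound 4, resting on compound 3 at > 20000 nM and on the parallel pair where compound 2 at > 20000 nM moved to compound 1 without leaving the limit.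

Compound 4 is accordingly estimated at 30000 nM in this assay, with an expected range from 8000 nM to 150000 nM and a high chance that only a limit is reported.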

Compound 4, inhibition constant: > 20000 nM
Compound 4: no number, only a limit; the forecaster's own chance of this, stated with the estimate: 85%; the middle value does not contradict the limit.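

No new step can be read: in this assay the change from compound 3 to compound 4 joins two limits of the assay, not two numbers. All compounds shown stand at the same point: the limit of > 20000 nM in this assay, at which 4 of the 4 values shown sit.

Left open is whether 4-(trifluoromethyl)phenyl to 4-methylphenyl alters inhibition on either core, and what structure would give a value that is a number rather than a limit.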